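The source may hold more compounds than are shown below. What is called first, only, known or untested is meant among the compounds shown, and "the series" means these compounds.

The study concerns a small set of compounds built on a shared core and examined in an assay on HEK293 cells for inhibition of cyclin-dependent kinase 14 (Homo sapiens), with a stated time of 4 h; on this read-out lower numbers stand for stronger inhibition and higher numbers for weaker inhibition. Compound 1, `CCC(=O)Nc1cccc(CN2CCC(NC(=O)c3n[nH]cc3NC(=O)c3c(Cl)cccc3Cl)CC2)c1`, gives in this assay only a limit of > 1000 nM, not a number. Compound 2, `CN(C)C/C=C/C(=O)Nc1cccc(C(=O)Nc2ccc(NC(=O)c3n[nH]cc3NC(=O)c3c(Cl)cccc3Cl)cc2)c1`, gives 1000 nM in this assay. Compound 3, `CN(C)C/C=C/C(=O)Nc1cccc(S(=O)(=O)N2CCC(NC(=O)c3n[nH]cc3NC(=O)c3ccccc3)CC2)c1`, gives 1000 nM in this assay, level with compound 2 at the digits shown and within the scatter of that value. Compound 4, `CN(C)C/C=C/C(=O)Nc1cccc(S(=O)(=O)N2CCC(NC(=O)c3n[nH]cc3NC(=O)c3c(Cl)cc(Cl)cc3Cl)CC2)c1`, has not yet been measured. It differs from compound 3 in one place: 2,4,6-trichlorophenyl in place of phenyl on a carbonyl carbon. Going by the values given here, no step between two measured compounds that differ in a single place is available, so the expectation rests on the values as they stand. Given that compound 2 gives 1000 nM and compound 3 gives 1000 nM, the expected step is no change at the digits printed from compound 3 to compound 4 (within the scatter), none beyond the scatter in this assay. Compound 4 is therefore estimated at 1000 nM in this assay, with a range from 400 nM to 2500 nM.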

Compound 4, half-maximal inhibitory concentration: >= 500 nM
Compound 4 ended at the assay's limit (the forecaster's own chance of this, stated with the estimate: 35%); the middle value does not contradict the limit.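

Going by these compounds alone, compound 4 gives >= 500 nM in this assay, which is a limit of the assay and not a number, so no step from compound 3 to compound 4 can be read. The compounds shown leave open how far 2,4,6-trichlorophenyl in place of phenyl on a carbonyl carbon shifts inhibition.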